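Swapping Methoxy for Methyl on a Weak Urea Series

The source may hold more compounds than are shown below. What is called first, only, known or untested is meant among the compounds shown, and "the series" means these compounds.

Compound 1, `O=C(Nc1ccc(I)cc1)N[C@H]1CC[C@H](Oc2ccc(F)cc2)CC1`, gives 10200 nM in a functional assay on CRL2813 cells (Homo sapiens) for cytotoxicity, read by sulforhodamine B assay, with a stated time of 5 days; on this read-out higher numbers stand for weaker inhibition and lower numbers for stronger inhibition.
Compound 2, `O=C(Nc1ccccc1[N+](=O)[O-])N[C@H]1CC[C@H](Oc2ccc(F)cc2)CC1`, gives 3500 nM in this assay.
Compound 3, `COc1ccccc1NC(=O)N[C@H]1CC[C@H](Oc2ccc(F)cc2)CC1`, gives > 20000 nM in this assay, and that is a limit of the assay, not a number.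

Compound 3 therefore stands at the weak end of what has been measured: it sits at the limit of > 20000 nM in this assay, at which 1 of the 3 values shown sits. The steps that reach it were an at least 1.9-fold higher number from compound 1 to compound 3 (0.29 log units; that floor lies within the scatter) and an at least 5.7-fold higher number from compound 2 to compound 3 (0.75 log units; beyond the scatter), so replacing the ring substituent has so far only pushed numbers upward. Compound 4, `Cc1ccccc1NC(=O)N[C@H]1CC[C@H](Oc2ccc(F)cc2)CC1`, differs from compound 3 by methyl in place of methoxy on an aromatic carbon. Going by the values given here, no measured step exchanges methoxy for methyl, so the expectation rests on compound 3 being at the limit. The expected step is a number no higher from compound 3 to compound 4 (the limit leaves the size open), no clear direction beyond the scatter. Compound 4 is estimated at 20000 nM, in a range from 8000 nM to 40000 nM.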

Compound 4, half-maximal inhibitory concentration: > 20000 nM
Compound 4 gave a limit, no number; the forecaster's own chance of this, stated with the estimate: 55%; the middle value lies on the limit itself.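

Methyl in place of nitro on this aromatic carbon gives an at least 5.7-fold higher number from compound 2 to compound 4 (0.75 log units; beyond the scatter), so methyl, like methoxy, falls short of nitro here. 2-Methylphenyl in place of 4-iodophenyl gives an at least 1.9-fold higher number from compound 1 to compound 4 (0.29 log units; that floor lies within the scatter), a floor too small to separate the two compounds. The step from methoxy to methyl cannot be read, as both values are limits of the assay, not numbers: the limit of > 20000 nM in this assay, at which 2 of the 4 values shown sit.

The compounds shown leave open how far apart methoxy and methyl truly lie. They also leave open whether an amine or a carboxylic acid on this aromatic carbon would track nitro or methyl.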